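Swapping Methyl for Hydroxy on a Carbonyl Carbon

A few compounds are considered here, and "the series" means these few. Any claim that something is new, unique, unknown or untested is made for them only; others in the source may bear on it.

Measured so far:
compound 1 `N#CCCSC(=S)NCc1cncs1` gives 296000 nM
compound 2 `N#CCCSC(=S)NCc1cnc2ccccc2c1` gives 96400 nM
compound 3 `CC(=O)CCSC(=S)NCc1cccnc1` gives 3430 nM

All three numbers come from a functional assay on Bel-7402 cells (Homo sapiens) for cytotoxicity, read by resazurin assay, with a stated time of 72 h; a lower number here means a stronger inhibitor, a higher number a weaker inhibitor. Among them compound 3 stands lowest, which in this assay means the strongest inhibitor of the three. The nearest number is that of compound 2, and the gap between the two values is well beyond the scatter of repeated measurements. Compound 1 sits further away still, its value being the highest of the three. No two of these compounds differ in one place only, so none of these gaps can be tied to a single structural change.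

Compound 4 `O=C(O)CCSC(=S)NCc1cccnc1` has not yet been measured. It differs from compound 3 in one place: hydroxy in place of methyl on a carbonyl carbon. Among the compounds with values here, nothing among the measured compounds shows what such a change does here. The expectation is nonetheless a move toward a higher number, beyond the scatter. Compound 4 is expected to give about 15000 nM, with a likely range from 3000 nM to 80000 nM. That estimate amounts to an expected step of a 4.4-fold higher number from compound 3 to compound 4 (0.64 log units; beyond the scatter).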

Compound 4, half-maximal inhibitory concentration: 7420 nM
Compound 4: middle estimate off by 2.0-fold (0.31 log units), on the high side; the range from low to high includes it.
By their numbers in this assay, from the lowest: compound 3; then compound 4; then compound 2; then compound 1.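

In this assay, within the data shown here, compounds 3 and 4 form the only pair here that differs in one place, so this is the first change whose size can be read directly. Replacing methyl with hydroxy on a carbonyl carbon, which turns the 2-acetylethyl group into a 2-carboxyethyl group, gives a 2.2-fold higher number from compound 3 to compound 4 (0.34 log units; beyond the scatter) as its step, a modest weakening that still lies beyond the scatter of repeated measurements, so this position accepts the change with only a small loss of strength. No measurement at hand accounts for this rise in the number and the result therefore records the size of the effect without giving its cause.

As far as these compounds go, whether an amine or a methoxy group on the same carbonyl carbon would give a stronger or a weaker inhibitor remains open, as does the effect of a longer chain carrying the carboxy group. It is also unknown whether the same exchange of methyl for hydroxy would give a step of similar size on the ring systems of compound 1 and compound 2, neither of which has a partner differing from it in one place.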